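Chloro in Place of Methoxy: A Small Change Weighed

The compounds below may be only part of what the source reports. "The series", "measured", "known", "first", "only" and "open" are said of these compounds alone.

Of the compounds shown here, three sharing one core have been measured in a functional assay on PC-12 cells (Rattus norvegicus) for cytotoxicity, read by MTT assay, with stated times of 3 h and 2 h, tested at 10 uM; a lower number here means a weaker effect, a higher number a stronger effect of the compound at the concentration tested. Compound 1 `O=C(CCCCC1CCSS1)NCc1cn(CCCOc2ccc3ccc(=O)oc3c2)nn1` gives 40%. Compound 2 `O=C(CCCCC1CCSS1)NCc1cn(CCCOc2ccc3cc(C(=O)O)c(=O)oc3c2)nn1`, which carries a carboxy in place of hydrogen on an aromatic carbon, gives 59.9%. Compound 3 `COc1ccc(-c2cc3ccc(OCCCn4cc(CNC(=O)CCCCC5CCSS5)nn4)cc3oc2=O)cc1`, which carries a 4-methoxyphenyl in place of hydrogen on an aromatic carbon, gives 57.6%. Compound 3 stands second highest of the three numbers, close to compound 2 and well apart from compound 1: the step of a number 17.6 percentage points higher from compound 1 to compound 3 (beyond the scatter) was modest, as was a number 19.9 percentage points higher from compound 1 to compound 2 (beyond the scatter), while a number 2.3 percentage points lower from compound 2 to compound 3 (within the scatter).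

Compound 4 `O=C(CCCCC1CCSS1)NCc1cn(CCCOc2ccc3cc(-c4ccc(Cl)cc4)c(=O)oc3c2)nn1` differs from compound 3 in one place: chloro in place of methoxy on an aromatic carbon. For the measured compounds named here, no measured step alters this part of the molecule. The nearest guide is the exchange of the whole group, carboxy to 4-methoxyphenyl, which stayed within the scatter, suggesting that the identity of the group attached there changes this assay little. Compound 4 is therefore expected to give about 57%, between 45% and 70%. For compound 4 this means an expected step of a number 0.6 percentage points lower from compound 3 to compound 4 (within the scatter), within the scatter.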

Compound 4, a percentage reported as activity, at one concentration (the size of the read-out at that concentration, not a potency): 67.8%
For compound 4 the middle estimate is 10.8 percentage points below the measured one; the range from low to high includes it.
By their numbers in this assay, from the lowest: compound 1; then compounds 3, 2 and 4 (each within the scatter of the next, the first and the last beyond it).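

In this assay, the far end of the added aromatic group turns out to matter: chloro in place of methoxy, on the same six-membered aromatic ring, gives a number 10.2 percentage points higher from compound 3 to compound 4 (beyond the scatter), so this small exchange moves the number even though the larger exchange of carboxy for 4-methoxyphenyl did not. The 4-chlorophenyl group still cannot be ranked against carboxy, with a number 7.9 percentage points higher from compound 2 to compound 4 (within the scatter), but compared with hydrogen on the shared core it gives a number 27.8 percentage points higher from compound 1 to compound 4 (beyond the scatter), the largest step in this small set. Nothing available here gives a cause for the chloro step.

A plain phenyl group, with hydrogen at this place, would show whether chloro raises the number, methoxy lowers it, or both. On these data alone, whether fluoro, bromo, a nitrile or an amine at the same place would read like chloro or like methoxy also remains open.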